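Halogen on the aryl ring: fluoro versus chloro

A few compounds are considered here, and "the series" means these few. Any claim that something is new, unique, unknown or untested is made for them only; others in the source may bear on it.

Measured compounds, with their read-outs in a functional assay on cells for antagonist activity at C-C chemokine receptor type 1 (Homo sapiens), read by FLIPR and calcium flux; on this read-out lower numbers stand for stronger inhibition and higher numbers for weaker inhibition:
compound 1, `Cc1c(C(=O)NCc2cccc(C(F)(F)F)c2)cnn1-c1ccc(Cl)c(Cl)c1` — compound 1 gives 500 nM
compound 2, `Cc1c(C(=O)NCc2cccc(C(F)(F)F)c2)cnn1-c1ccccc1` — compound 2 gives only a limit of the assay, > 3000 nM
compound 3, `Cc1c(C(=O)NCc2cccc(C(F)(F)F)c2)cnn1-c1ccc(F)cc1` — compound 3 gives 790 nM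
compound 4, `Cc1c(C(=O)NCc2cccc(C(F)(F)F)c2)cnn1-c1ccc(Cl)cc1` — not yet measured

Compound 3 and compound 1 sit within the scatter of each other, a 1.6-fold higher number from compound 1 to compound 3 (0.20 log units; within the scatter); the third value shown is a limit, (the limit of > 3000 nM in this assay, at which 1 of the 3 values shown sits), so compound 3 can be placed only against compound 1. The two steps beyond the scatter both involve compound 2: an at least 6.0-fold higher number from compound 1 to compound 2 (0.77 log units; beyond the scatter) and an at least 3.7-fold lower number from compound 2 to compound 3 (0.57 log units; beyond the scatter). A halogen on the aryl ring is thus tied to a clearly lower number than hydrogen there, while fluoro against dichloro makes no difference beyond the scatter.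

Compound 4 carries chloro in place of fluoro on an aromatic carbon. Both bearing steps point to a halogen on this ring being what matters, not which one; the dichloro compound 1 lies within the scatter of compound 3. Compound 4 is therefore expected to show a 1.6-fold lower number from compound 3 to compound 4 (0.20 log units; within the scatter), a small shift toward a lower number at most. The estimate for compound 4 is 500 nM, with a range of 200 nM to 1300 nM.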

Compound 4, half-maximal inhibitory concentration: 600 nM
For compound 4 the middle estimate is 1.2-fold (0.08 log units) below the measured one; low and high end bracket the measured number.
By their numbers in this assay, from the lowest: compounds 1, 4 and 3 (each within the scatter of the next). At a limit, above all of these: compound 2.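

In this assay, chloro in place of fluoro gives a 1.3-fold lower number from compound 3 to compound 4 (0.12 log units; within the scatter), so at this place, para to a large group, the two halogens cannot be told apart. Going from the 3,4-dichlorophenyl group to the 4-chlorophenyl group gives a 1.2-fold higher number from compound 1 to compound 4 (0.08 log units; within the scatter), so the second chloro adds nothing that can be read beyond the scatter. Chloro in place of hydrogen gives an at least 5.0-fold lower number from compound 2 to compound 4 (0.69 log units; beyond the scatter), which confirms for chloro what fluoro had shown, and this step rests on the value of compound 2, which is a limit: the limit of > 3000 nM in this assay, at which 1 of the 4 values shown sits.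

On these data alone, it remains open whether bromo at this place would read like fluoro and chloro. As far as these compounds go, it also remains open whether a non-halogen group such as methoxy or nitrile would do the same.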